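This account rests on a few compounds, and the source may have more. Where it says the series, first, only, none or still open, it means among the compounds named here.

Compound 1, `O=C(O)CCc1ccc(OCc2ccc(Oc3ccccc3)cc2)cc1`, gave 98% in a functional assay on 1321-N1 cells for agonist activity at Free fatty acid receptor 1 (Homo sapiens), read by calcium flux; a lower number here means a smaller maximal response, a higher number a larger maximal response.
Compound 2, `O=C(O)CCc1ccc(NCc2ccc(Oc3ccccc3)cc2)cc1`, gave 100% in this assay.
Compound 3, `O=C(O)CCc1ccc(OCc2ccc(-c3ccccc3)cc2)cc1`, gave 97% in this assay.

Compound 1 and compound 3 differ in a single place: phenyl in place of phenoxy on an aromatic carbon. In this assay that step was a number 1 percentage points lower from compound 1 to compound 3 (within the scatter), so the two responses are indistinguishable. Compound 2 differs from compound 1 in the core; the difference between the two cores is not broken down here. Its value in this assay lies within the scatter of both compound 1 and compound 3, so no order among the three can be read.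

Compound 4, `O=C(O)CCc1ccc(NCc2ccc(-c3ccccc3)cc2)cc1`, has not yet been measured. It arises from compound 2 by the same change seen between compound 1 and compound 3, namely (phenyl in place of phenoxy on an aromatic carbon), at a place described in identical words. The step from compound 2 to compound 4 is therefore expected to be small, a number 1 percentage points lower from compound 2 to compound 4 (within the scatter), because a number 1 percentage points lower from compound 1 to compound 3 (within the scatter). On that basis compound 4 is estimated to reach 99% in this assay, with the expected range running from 90% to 105%.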

Compound 4, largest response reached (reported as efficacy), in percent of the reference or control that the assay uses: 92%
For compound 4 the middle estimate is 7 percentage points above the measured one; low and high end bracket the measured number.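

On the core of compound 2, phenyl in place of phenoxy gave, in this assay, a number 8 percentage points lower from compound 2 to compound 4 (within the scatter), so compound 4 cannot be told apart from compound 2. Set beside the same change on the core of compound 1, the new step does not differ from the earlier one: the same change on two cores in this assay, a number 1 percentage points lower (within the scatter) from compound 1 to compound 3 and a number 8 percentage points lower (within the scatter) from compound 2 to compound 4, 7 percentage points apart, within the scatter of two such steps. The change therefore carries over between these two cores with no measurable difference in maximal response, but this rests on a single pair of steps and does not show that it would behave alike on any other core, or that the two cores would agree in a read-out other than maximal response.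

The compounds shown leave open whether a group other than phenoxy or phenyl, such as a benzyl group or a pyridine ring, would keep the maximal response at this place. They also leave open what a tetrazole in place of the carboxylic acid, or a shorter chain bearing it, would do.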